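Notes on the side-chain rearrangement from compound 3

The source may report more compounds than this note shows. Statements on the series, on what has been measured and on what is new or still open speak of the compounds shown alone.

Compound 3 `Cc1cc(C(=O)Nc2ccc(Cl)cc2)ccc1N(CC(=O)N1CCOCC1)C(=O)Nc1ccc(Cl)cc1` stands at the top of the three numbers in an ADME assay on microsomes from liver (Canis lupus familiaris) for metabolic stability (a higher number here means that the compound lasts longer, a lower number that the compound disappears faster), giving 0.617 h, though the gap to compound 1 is within the scatter. Compound 1 `Cc1cc(C(=O)Nc2ccc(F)cn2)ccc1N(CCN1CCCC1)C(=O)Nc1ccc(Cl)cc1` gives 0.558 h in this assay. Compound 2 `Cc1cc(C(=O)Nc2ccc(F)cn2)ccc1N(CCN1CCCC1=O)C(=O)Nc1ccc(Cl)cc1` gives 0.0517 h, beyond the scatter from both of the others.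

Compound 4 `Cc1cc(C(=O)Nc2ccc(Cl)cc2)ccc1N(CCN1CCOCC1=O)C(=O)Nc1ccc(Cl)cc1` differs from compound 3 by (3-oxomorpholin-4-yl)methyl in place of (morpholin-4-yl)carbonyl on a saturated chain carbon bound to an amide-type nitrogen. Among the compounds with values here, no measured step covers this exact rearrangement, in which the same atoms are joined differently. Within the data shown here, the one step that bears on it is an 11-fold lower number from compound 1 to compound 2 (1.03 log units; beyond the scatter), where a 2-oxopyrrolidin-1-yl replaced a pyrrolidin-1-yl on the chain; the 3-oxomorpholin-4-yl entering in compound 4 resembles that group. The cases are not alike in every way, since compound 3 already carries a carbonyl on its chain and compound 1 did not. A lower number is nevertheless expected for compound 4, given how far compound 2 fell to 0.0517 h, but a smaller drop than that one is expected. The expected step is a 3.1-fold lower number from compound 3 to compound 4 (0.49 log units; beyond the scatter). Compound 4 is estimated at 0.2 h in this assay, with a range from 0.06 h to 0.6 h.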

Compound 4, half-life: 0.215 h
For compound 4 the middle estimate is 1.1-fold (0.03 log units) below the measured one, within the range that was stated.
By their numbers in this assay, from the lowest: compound 2; then compound 4; then compounds 1 and 3 (each within the scatter of the next).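

Moving the carbonyl from the chain into the ring gives a 2.9-fold lower number from compound 3 to compound 4 (0.46 log units; beyond the scatter), so at this saturated chain carbon bound to an amide-type nitrogen, this assay distinguishes two groups with identical counts of heavy atoms, rings, double bonds, donors and acceptors. The counts printed for (morpholin-4-yl)carbonyl and (3-oxomorpholin-4-yl)methyl therefore do not predict the read-out here, and how the same atoms are joined is enough to move it beyond the scatter. With an 11-fold lower number from compound 1 to compound 2 (1.03 log units; beyond the scatter) as the other listed step, both changes that bring a ring carbonyl onto this chain go towards a lower number, with no compound shown against this, although the two steps start from different groups and different cores, and nothing measured here explains the fall in either case.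

The compounds shown leave open where a plain 2-(morpholin-4-yl)ethyl, an amine with no carbonyl on the chain or in the ring, would stand on the core of compound 3 relative to compound 3 and compound 4. Also open, as far as these compounds go, is whether a longer chain, such as 3-(3-oxomorpholin-4-yl)propyl, would keep or change the number seen for compound 4.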